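A few compounds are considered here, and "the series" means these few. Any claim that something is new, unique, unknown or untested is made for them only; others in the source may bear on it.

Within the data shown here, compound 2, `CCCCCCCCCCCCC/C=C/[C@@H](O)[C@@H](COP(=O)(O)O)N=[N+]=[N-]`, gives 22900 nM in an assay on isolated protein for inhibition of sphingosine-1-phosphate lyase 1 (Homo sapiens), read by fluorescence, with a stated time of 1 h (a lower number here means a stronger inhibitor, a higher number a weaker inhibitor), the lowest of the two numbers measured so far. The nearest is compound 1, `CCCCCCCCCCCCC/C=C/[C@H](O)[C@H](COP(=O)(O)O)N=[N+]=[N-]`, which gives 28800 nM in this assay, and the step of a 1.3-fold lower number from compound 1 to compound 2 (0.10 log units; within the scatter) falls within the scatter. Compound 3, `CCCCCCCCCCCCC/C=C/[C@H](O)[C@@H](COP(=O)(O)O)N=[N+]=[N-]`, has not yet been measured in this assay. Its difference from compound 2 is the two compounds have the same atoms and bonds; at least one stereo element is drawn with a configuration in one of them and without one in the other: 1 of 4 stereo elements differ; a stereocentre at a saturated chain carbon is drawn R in compound 2 and S in compound 3.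

Among the measured compounds shown here, only one measured step bears on this change: a 1.3-fold lower number from compound 1 to compound 2 (0.10 log units; within the scatter), in which two stereocentres at saturated chain carbons were inverted together and the number moved by an amount within the scatter. The one remark recorded on that step is the fact that one of compounds 1 and 2 is drawn with a defined configuration and the other without, at the place where they differ, which adds nothing on direction. Inverting a single stereocentre at a saturated chain carbon in compound 2 is therefore expected to produce no step beyond the scatter in this assay, and the expected step is a 1.1-fold higher number from compound 2 to compound 3 (0.04 log units; within the scatter). Compound 3 is estimated at 25000 nM in this assay, with a range from 10000 nM to 65000 nM.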

Compound 3, half-maximal inhibitory concentration: 5200 nM
Compound 3: the middle estimate sits 4.8-fold (0.68 log units) above what was measured; measured number below the stated range.
By their numbers in this assay, from the lowest: compound 3; then compounds 2 and 1 (each within the scatter of the next).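

The result shows that the two stereocentres at saturated chain carbons are not interchangeable in this assay: inverting just one of them gives a 4.4-fold lower number from compound 2 to compound 3 (0.64 log units; beyond the scatter), and inverting just the other gives a 5.5-fold lower number from compound 1 to compound 3 (0.74 log units; beyond the scatter). Compounds 1 and 2 alone could not show this, since inverting both stereocentres together left their numbers within the scatter of each other, so a flat response to configuration was a reasonable reading of that pair, whereas compound 3, with its mixed arrangement of the two centres, now stands as the strongest inhibitor of the three, with both of its steps beyond the scatter. The structural remarks recorded for these pairs only note that the compounds differ in drawn configuration, and nothing recorded explains why this arrangement gives the lower number.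

The compounds shown leave open how the fourth arrangement of these two stereocentres would read, and so whether the two inversions act independently. They also leave open whether the same preference would hold with an amine in place of the azide, a carboxylic acid in place of the phosphate, or a longer chain.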